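The source may report more compounds than this note shows. Statements on the series, on what has been measured and on what is new or still open speak of the compounds shown alone.

Measured in a functional assay on MGC-803 cells (Homo sapiens) for inhibition, read by MTT assay, with a stated time of 72 h; on this read-out higher numbers stand for weaker inhibition and lower numbers for stronger inhibition
compound 1 `CN1CCN(c2cc(C(F)(F)F)nc(SCc3ccc(C(F)(F)F)cc3)n2)CC1` gives 15800 nM
compound 2 `CCN1CCN(c2cc(C(F)(F)F)nc(SCc3ccc(C(F)(F)F)cc3)n2)CC1` gives 25600 nM
compound 3 `FC(F)(F)c1ccc(CSc2nc(Sc3ncccn3)cc(C(F)(F)F)n2)cc1` gives 28600 nM

Compound 3, at 28600 nM, stands level with the other two compounds, since its numbers differ from theirs by no more than the usual scatter between repeated measurements. Compound 4 `FC(F)(F)c1ccc(CSc2nc(Sc3nnnn3-c3ccccc3)cc(C(F)(F)F)n2)cc1` keeps the rest of compound 3 and changes one group, with 1-phenyl-1H-tetrazol-5-yl in place of pyrimidin-2-yl on a sulfur.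

Going by the values given here, no measured pair changes the group on that sulfur, so the evidence is only indirect. The closest guide is the exchange of a whole group on an aromatic carbon. Putting (pyrimidin-2-yl)sulfanyl in place of 4-methylpiperazin-1-yl gave a 1.8-fold higher number from compound 1 to compound 3 (0.26 log units; within the scatter), and putting it in place of 4-ethylpiperazin-1-yl gave a 1.1-fold higher number from compound 2 to compound 3 (0.05 log units; within the scatter). Neither exchange moved the number beyond the scatter, so no step beyond the scatter is expected in this assay, and no direction can be favoured with confidence. The expected step is a 1.3-fold lower number from compound 3 to compound 4 (0.11 log units; within the scatter). The estimate for compound 4 is 22000 nM, with an expected range of 8000 nM to 50000 nM.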

Compound 4, half-maximal inhibitory concentration: 12400 nM
Estimate against measurement, compound 4: 1.8-fold (0.25 log units) above; low and high end bracket the measured number.
By their numbers in this assay, from the lowest: compounds 4, 1, 2 and 3 (each within the scatter of the next, the first and the last beyond it).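

Going by these compounds alone, changing the group on this sulfur gives the first step in this assay that lies beyond the usual scatter: with 1-phenyl-1H-tetrazol-5-yl in place of pyrimidin-2-yl, the result is a 2.3-fold lower number from compound 3 to compound 4 (0.36 log units; beyond the scatter), which points to stronger inhibition. The earlier exchanges stayed within the scatter, whereas this one shows that the group on this sulfur can move the number, if only modestly. No measurement shown explains why this step occurs.

Going by these compounds, the entering group brings a five-membered aromatic ring and a phenyl ring together, so the contribution of each remains open; a 1-methyl-1H-tetrazol-5-yl group on the same sulfur would help separate them. Also open, on these data alone, is whether a simple phenyl group on this sulfur would do as well.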